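Replacing the aminophenyl on the shared core with methoxyphenyl

This account rests on a few compounds, and the source may have more. Where it says the series, first, only, none or still open, it means among the compounds named here.

Compound 1 `COc1ccc(-c2cc3ccccc3c(-c3cccc(O)c3)n2)cc1`: 9.4%
Compound 2 `COc1ccc(-c2cc3cc(C)ccc3c(-c3cccc(O)c3)n2)cc1OC`: 1.7%
Compound 3 `COc1ccc(-c2cc3cc(C)ccc3c(-c3cccc(N)c3)n2)cc1OC`: 7.2%

In an assay on isolated protein for inhibition of DNA topoisomerase 1 (Homo sapiens), with a stated time of 30 min, tested at 100 uM (on this read-out higher numbers stand for a stronger effect at the one concentration tested and lower numbers for a weaker effect), compound 3 gives 7.2%, the second highest of the three numbers; compound 1 gives 9.4% and compound 2 gives 1.7%, and both lie within the scatter of the number for compound 3. Compound 4 `COc1ccc(-c2nc(-c3ccc(OC)c(OC)c3)cc3cc(C)ccc23)cc1` differs from compound 3 by 4-methoxyphenyl in place of 3-aminophenyl on an aromatic carbon. Going by the values given here, the only measured step at this position, a number 5.5 percentage points higher from compound 2 to compound 3 (within the scatter), stayed within the scatter, and no measured step exchanges 3-aminophenyl for 4-methoxyphenyl. With all three numbers low and no step beyond the scatter, the expected change is a number 2.2 percentage points lower from compound 3 to compound 4 (within the scatter). Compound 4 is therefore estimated at 5%, between 0% and 15%.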

Compound 4, a percentage reported as inhibition, at one concentration (the size of the read-out at that concentration, not a potency): 2.3%
Estimate against measurement, compound 4: 2.7 percentage points above; measured number inside the range.
By their numbers in this assay, from the lowest: compounds 2, 4, 3 and 1 (each within the scatter of the next).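

With 4-methoxyphenyl, the position next to the ring nitrogen has now carried a third group, and this assay still separates none of the three (a number 4.9 percentage points lower from compound 3 to compound 4 (within the scatter); a number 0.6 percentage points higher from compound 2 to compound 4 (within the scatter)). Exchanging 3-aminophenyl, with its hydrogen-bond donor, for 4-methoxyphenyl, which has none, thus leaves the number within the scatter. No evidence here accounts for these numbers.

Going by these compounds, whether a carboxylic acid or an aminoalkyl chain at this position would move the number beyond the scatter stays open. So does the effect of a 3-methoxyphenyl group there.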